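This account rests on a few compounds, and the source may have more. Where it says the series, first, only, none or still open, it means among the compounds named here.

Series notes in an ADME assay on S9 fraction from liver (Rattus norvegicus) for metabolic stability, read by LC-MS, using NADPH, with a stated time of 30 min; on this read-out lower numbers stand for a less stable compound and higher numbers for a more stable compound. Compound 1 `CCCCCCCCc1ccc(OCC(=O)Cn2nnc(C)n2)cc1` carries methyl on the shared core; in this assay compound 1 sits at < 5%, which is a limit of the assay and not a number. For the measured compounds named here, compound 2 `CCCCCCCCc1ccc(OCC(=O)Cn2nnc(-c3cccc(Cl)c3)n2)cc1` carries 3-chlorophenyl in its place, and in this assay compound 2 gives 69%, the only number so far. The other value shown is that of compound 1, which sits at the limit of < 5% in this assay, at which 1 of the 2 values shown sits. Going by the values given here, the single measured step, a number at least 64 percentage points higher from compound 1 to compound 2 (beyond the scatter), is therefore the whole of what is known about the effect of structure on this read-out.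

Compound 3 `CCCCCCCCc1ccc(OCC(=O)Cn2nnc(-c3ccncc3)n2)cc1` differs from compound 2 by pyridin-4-yl in place of 3-chlorophenyl on an aromatic carbon. Among the compounds with values here, no measured step exchanges one six-membered aromatic group for another; the one step available, methyl to 3-chlorophenyl, was large, but it says nothing about pyridin-4-yl against 3-chlorophenyl. The expected step is a number 14 percentage points lower from compound 2 to compound 3 (beyond the scatter), modest and downward, or none beyond the scatter. For compound 3 in this assay the estimated value is 55%, with an expected range from 25% to 85%.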

Compound 3, percent of the compound remaining: < 5%
Compound 3 gave a limit, no number; the forecaster's own chance of this, stated with the estimate: 5%; middle value at least 50 percentage points away from the limit.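

In this assay the exchange of 3-chlorophenyl for pyridin-4-yl, on an aromatic carbon of the five-membered aromatic ring with 4 nitrogen, is a number at least 64 percentage points lower from compound 2 to compound 3 (beyond the scatter), and the value of compound 3 behind this step is a limit of the assay and not a number. Compound 2 and compound 3 both carry a six-membered aromatic ring at this place, yet only compound 2 stands clear of the limit, so the presence of such a ring alone does not account for the earlier gain, and the read-out depends on which ring is there. Compound 1 and compound 3 both carry limits, and the step between them cannot be read: the limit of < 5% in this assay, at which 2 of the 3 values shown sit.

Compound 2 and compound 3 differ both in the chlorine and in the ring nitrogen, and the pair cannot separate these two changes; a plain phenyl group at this place would bear directly on that question. Also open, on these data alone, is how far the read-out follows the ring nitrogen's location, which pyridin-3-yl would test against pyridin-4-yl.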